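Pyridin-2-yl for 1,3-thiazol-2-yl: next step from compound 2

A few compounds are considered here, and "the series" means these few. Any claim that something is new, unique, unknown or untested is made for them only; others in the source may bear on it.

Measured so far:
compound 1 `CC(C)=CCOc1cc(Nc2nccs2)ccc1C(C)C`: 31000 nM
compound 2 `CC(C)=CCOc1cc(Nc2nccs2)ccc1C#N`: 750 nM

Among the compounds with values here, compound 2 stands lowest of the two numbers in a functional assay on MT2 cells (Homo sapiens) for cytotoxicity, read by MTT assay; on this read-out lower numbers stand for higher toxicity in this test and higher numbers for lower toxicity in this test; the only measured step is a 41-fold lower number from compound 1 to compound 2 (1.62 log units; beyond the scatter), and that step concerns the cyano on an aromatic carbon. Compound 3 `CC(C)=CCOc1cc(Nc2ccccn2)ccc1C#N` differs from compound 2 in one place: pyridin-2-yl in place of 1,3-thiazol-2-yl on a nitrogen on an aromatic ring. Within the data shown here, no measured step touches this place, so nothing bears on it directly. No step beyond the scatter is therefore expected in this assay, but the range must be wide. Compound 3 is estimated at 1500 nM (range 400 nM to 6000 nM), which means an expected step of a 2.0-fold higher number from compound 2 to compound 3 (0.30 log units; within the scatter).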

Compound 3, half-maximal cytotoxic concentration: 290 nM
Compound 3: middle estimate off by 5.2-fold (0.71 log units), on the high side, outside the stated range (below it).
By their numbers in this assay, from the lowest: compound 3; then compound 2; then compound 1.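

In this assay, the thiazole is not needed for the low number, since replacing it with pyridin-2-yl on the same nitrogen gives a 2.6-fold lower number from compound 2 to compound 3 (0.41 log units; beyond the scatter), a modest step beyond the scatter. This second place in the series therefore also affects toxicity in this test, and a six-membered aromatic ring with 1 hetero atom is tolerated there. No supporting evidence is available to account for the step.

Phenyl or pyrimidin-2-yl on that nitrogen would test whether the ring nitrogen count matters. As far as these compounds go, whether the step persists with isopropyl in place of cyano remains open.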